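Cytotoxicity in a rhodanine series: bromo for hydroxy

The source may report more compounds than this note shows. Statements on the series, on what has been measured and on what is new or still open speak of the compounds shown alone.

Measured so far:
compound 1 `Cc1cc(/C=C2\SC(=S)N(c3ccccc3)C2=O)c(C)n1-c1cccc(-c2nnn[nH]2)c1` — 61000 nM
compound 2 `Cc1cc(/C=C2\SC(=S)N(c3cccc(O)c3)C2=O)c(C)n1-c1cccc(-c2nnn[nH]2)c1` — 35600 nM

Going by the values given here, in an ADME assay on MT2 cells (Homo sapiens) for cytotoxicity, read by XTT assay, with a stated time of 4 days (a higher number here means that more compound is tolerated, a lower number that less compound is tolerated), compound 2 gives the lowest of the two numbers, and its nearest neighbour is compound 1; the one measured step, a 1.7-fold lower number from compound 1 to compound 2 (0.23 log units; within the scatter), lies within the scatter. Compound 3 `Cc1cc(/C=C2\SC(=S)N(c3cccc(Br)c3)C2=O)c(C)n1-c1cccc(-c2nnn[nH]2)c1` differs from compound 2 by bromo in place of hydroxy on an aromatic carbon. Among the compounds with values here, no measured step exchanges one substituent for another at this carbon, so the only guide is that a change at this position gave no step beyond the scatter. No step beyond the scatter is therefore expected for a 1.1-fold higher number from compound 2 to compound 3 (0.05 log units; within the scatter). Compound 3 is estimated at 40000 nM, with a range of 15000 nM to 100000 nM.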

Compound 3, half-maximal cytotoxic concentration: 22600 nM
Compound 3: the middle estimate sits 1.8-fold (0.25 log units) above what was measured; the range from low to high includes it.
By their numbers in this assay, from the lowest: compounds 3, 2 and 1 (each within the scatter of the next, the first and the last beyond it).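

Bromo in place of hydroxy gives a 1.6-fold lower number from compound 2 to compound 3 (0.20 log units; within the scatter) in this assay and so does not separate these two substituents at this carbon. Bromo in place of hydrogen gives a 2.7-fold lower number from compound 1 to compound 3 (0.43 log units; beyond the scatter) and is thus the only change at this carbon with a step beyond the scatter, though a modest one. Nothing available bears on the cause of this step.

Whether this step is particular to bromo remains open, since only hydroxy and bromo are shown here. An amine, a methoxy group or a carboxylic acid on the same carbon would test this.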